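Triazole aryl swap on an inactive spirooxindole pair

The source may hold more compounds than are shown below. What is called first, only, known or untested is meant among the compounds shown, and "the series" means these compounds.

Measured compounds:
compound 1, `N#CC1=C(N)Oc2c(c3nc4ccccc4nc3c3ccccc23)C12C(=O)N(Cc1cnnn1-c1ccccc1Cl)c1ccccc12`: in a functional assay on HCT-116 cells (Homo sapiens) for antiproliferative activity, read by MTT assay, with a stated time of 48 h (a lower number here means a stronger inhibitor, a higher number a weaker inhibitor), compound 1 gives > 50000 nM, a limit of the assay.
compound 2, `COc1ccccc1-n1nncc1CN1C(=O)C2(C(C#N)=C(N)Oc3c(N)cc4nc5ccccc5nc4c32)c2ccccc21`: in this assay compound 2 gives > 50000 nM, a limit of the assay.

Going by the values given here, compound 2 stands at the limit of this assay and not at a number; the same holds for the only other value shown, so the limit of > 50000 nM in this assay, at which 2 of the 2 values shown sit, is all the evidence there is. Among the compounds with values here, compound 1 and compound 2 differ in more than one place, so no single step between measured compounds can be read from them; the two values show only that both sit at the limit.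

Compound 3, `N#CC1=C(N)Oc2c(N)cc3nc4ccccc4nc3c2C12C(=O)N(Cc1cnnn1-c1ccc(F)c(Cl)c1)c1ccccc12`, is the next compound to be measured in this assay. Against compound 2 the change is 3-chloro-4-fluorophenyl in place of 2-methoxyphenyl on an aromatic nitrogen. Neither of the measured compounds gives a number, so there is nothing from which the size of a step in this assay can be read; the step from compound 2 to compound 3 is expected to stay within the scatter, with the value again most likely at the limit.

The estimated step is a step that the limit leaves unreadable from compound 2 to compound 3, as an expectation only. Compound 3 is expected to give about 60000 nM, in the range 15000 nM to 200000 nM.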

Compound 3, half-maximal inhibitory concentration: > 50000 nM
Compound 3: a limit, no number (the forecaster's own chance of this, stated with the estimate: 80%); the middle value is on the limit's open side.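

No step can be read from compound 2 to compound 3, as both stand at a limit of the assay and not at a number: the limit of > 50000 nM in this assay, at which 3 of the 3 values shown sit.

The compounds shown leave open what 3-chloro-4-fluorophenyl in place of 2-methoxyphenyl does to potency, and whether anything on the shared core gives a number in this assay.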